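Swapping Methoxy for Chloro on the Shared Core

This account rests on a few compounds, and the source may have more. Where it says the series, first, only, none or still open, it means among the compounds named here.

For the measured compounds named here, compound 1 `COc1ncc(-c2ccc3nc(NC4CC4)sc3c2)cc1NS(=O)(=O)c1ccc(F)cc1` was tested in a functional assay on HCT-116 cells (Homo sapiens) for antiproliferative activity, read by MTT assay, with a stated time of 72 h (a higher number here means a weaker inhibitor, a lower number a stronger inhibitor), where compound 1 gives 1560 nM, the highest of the two numbers measured so far. Going by the values given here, its only measured neighbour is compound 2 `COc1ncc(-c2ccc3nc(NC(=O)NCCN4CCCCC4)sc3c2)cc1NS(=O)(=O)c1ccc(F)cc1`, which in this assay gives 610 nM. That step, a 2.6-fold lower number from compound 1 to compound 2 (0.41 log units; beyond the scatter), came from putting (2-(piperidin-1-yl)ethyl)carbamoyl in place of cyclopropyl on a nitrogen on an aromatic ring. Compound 3 `O=S(=O)(Nc1cc(-c2ccc3nc(NC4CC4)sc3c2)cnc1Cl)c1ccc(F)cc1` has not yet been measured. It differs from compound 1 elsewhere: chloro in place of methoxy on an aromatic carbon. Among the compounds with values here, the single measured step changed another part of the molecule, so no measured step bears directly on this exchange, and the data give no guide to its direction. A step within the scatter is therefore expected, a 1.0-fold lower number from compound 1 to compound 3 (0.02 log units; within the scatter). Compound 3 is estimated at 1500 nM, with a range from 600 nM to 4000 nM.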

Compound 3, half-maximal inhibitory concentration: 5750 nM
Compound 3: middle estimate off by 3.8-fold (0.58 log units), on the low side; the whole stated range lies below it.
By their numbers in this assay, from the lowest: compound 2; then compound 1; then compound 3.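

At this position the group matters: in this assay, chloro in place of methoxy next to the ring nitrogen gives a 3.7-fold higher number from compound 1 to compound 3 (0.57 log units; beyond the scatter) and so a weaker inhibitor. For the compounds shown here, this is the first measured change on this aromatic carbon, and the earlier step, made elsewhere on the molecule, could not show that this carbon is sensitive to what it carries, even in an exchange of only two heavy atoms for one that also removes one hydrogen-bond acceptor. Nothing measured here accounts for the rise in the number.

Still open, on these data alone, is how other groups on this carbon, such as methyl, ethoxy or an amine, would compare with methoxy and chloro. Also open, as far as these compounds go, is whether chloro in place of methoxy would give a step of similar size on compound 2.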